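This account rests on a few compounds, and the source may have more. Where it says the series, first, only, none or still open, it means among the compounds named here.

Measured so far in an assay on cell membranes from spleen (Cavia porcellus) for binding affinity to leukotriene B4 receptor 1 (Homo sapiens); on this read-out lower numbers stand for stronger inhibition and higher numbers for weaker inhibition:
Compound 1 `COC(=O)CCCCCOc1cc(-c2ccccc2)cc(-c2ccccc2)n1`: 40 nM
Compound 2 `O=C(O)CCCCCOc1cc(-c2ccccc2)cc(-c2ccccc2)n1`: 3 nM

Compound 2 stands lowest of the two numbers in this assay; its only neighbour is compound 1, and the single measured step, a 13-fold lower number from compound 1 to compound 2 (1.12 log units; beyond the scatter), is the whole of what the series has shown so far. Compound 3 `CC(C)(CCCCCCOc1cc(-c2ccccc2)cc(-c2ccccc2)n1)C(=O)O` is the next member. Its change from compound 2 reads: 2-carboxy-2-methylpropyl in place of carboxy on a saturated chain carbon, five bonds along the chain from an oxygen on an aromatic ring. The acid end of compound 2 is kept; what changes is the chain that carries it. Among the compounds with values here, the one measured step bears on the ester-to-acid exchange, not on chain length or branching, so it shows only that the free acid of compound 2 gave the lower number, and it sets no direction for the added carbons. Within the data shown here, no pair among the measured compounds differs in the chain, so the step to compound 3 has no precedent here. The expected step is therefore small, with wide uncertainty either way: a 2.0-fold higher number from compound 2 to compound 3 (0.30 log units; within the scatter). Compound 3 is estimated at 6 nM, with a range from 1.5 nM to 25 nM.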

Compound 3, half-maximal inhibitory concentration: 22 nM
The estimate for compound 3 lay 3.7-fold (0.56 log units) below the measured number; measured number inside the range.
By their numbers in this assay, from the lowest: compound 2; then compounds 3 and 1 (each within the scatter of the next).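

In this assay, within the data shown here, this is the first change to the chain at this saturated chain carbon, five bonds along the chain from an oxygen on an aromatic ring, and 2-carboxy-2-methylpropyl in place of carboxy is not tolerated without cost (a 7.3-fold higher number from compound 2 to compound 3 (0.87 log units; beyond the scatter)). A carboxy end alone therefore does not secure the low number of compound 2: with the acid kept but the chain altered, the result does not separate from the methyl ester (a 1.8-fold lower number from compound 1 to compound 3 (0.26 log units; within the scatter)). The series thus shows that the number at this position depends on the chain carrying the acid as well as on the free acid, but no measurement available here explains the loss.

The compounds shown do not separate the effect of the added chain carbons from that of the methyl branching, so an unbranched longer chain ending in a carboxylic acid would be the direct test of which one carries the step. Also open, going by these compounds, is how a shorter chain, or a primary amide or tetrazole at the chain end, would read.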